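The compounds below may be only part of what the source reports. "The series", "measured", "known", "first", "only" and "open" are said of these compounds alone.

Measured compounds in a functional assay on SK-OV-3 cells (Homo sapiens) for cytotoxicity, read by MTT assay; on this read-out lower numbers stand for stronger inhibition and higher numbers for weaker inhibition:

Compound 1 `C/C1=C/C2=C(CC(C)(C)[C@@H]2O)[C@H](C)CC[C@@H]1O`: in this assay compound 1 gives > 10 ug/mL, a limit of the assay.
Compound 2 `C/C1=C/C2=C(CC(C)(C)[C@H]2O)[C@H](C)CC[C@@H]1O`: in this assay compound 2 gives > 10 ug/mL, likewise a limit.
Compound 3 `CC(=O)CC/C=C(/C)CC1=CC(C)(C)CC1=O`: in this assay compound 3 gives > 10 ug/mL, also a limit.

Compound 3 therefore stands at the limit of > 10 ug/mL in this assay, at which 3 of the 3 values shown sit, no number being known for it. Among the measured compounds shown here, the only measured step, a step that the two limits leave unreadable from compound 1 to compound 2, rests on the fact that compounds 1 and 2 differ only in the configuration as drawn and is left unreadable by the limit of > 10 ug/mL in this assay, at which 3 of the 3 values shown sit.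

Compound 4 `C/C(=C/CC[C@H](C)O)CC1=CC(C)(C)CC1=O` differs from compound 3 in one place: 1-hydroxyethyl in place of acetyl on a saturated chain carbon, two bonds along the chain from a double-bonded chain carbon. For the measured compounds named here, no measured step bears on an exchange of acetyl for 1-hydroxyethyl, so no direction beyond the scatter can be expected for a step that the limit leaves unreadable from compound 3 to compound 4. Compound 4 is accordingly expected at 20 ug/mL, within 8 ug/mL to 60 ug/mL, most likely again reported as a limit.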

Compound 4, half-maximal inhibitory concentration: > 10 ug/mL
Compound 4 gave a limit, no number; the forecaster's own chance of this, stated with the estimate: 80%; the middle value lies beyond the limit too.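

The exchange of acetyl for 1-hydroxyethyl from compound 3 to compound 4 gives no readable step: the limit of > 10 ug/mL in this assay, at which 4 of the 4 values shown sit.

Going by these compounds, whether this exchange, or the configuration that separates compound 1 from compound 2, changes cytotoxicity at all remains open.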